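A few compounds are considered here, and "the series" means these few. Any claim that something is new, unique, unknown or untested is made for them only; others in the source may bear on it.

Two compounds share one core and differ in a single place. Compound 1 `Nc1ccc(-c2cc(=O)c3c(N)c(F)c(Cl)c(F)c3o2)cc1F` carries a chloro group where compound 2 `Nc1ccc(-c2cc(=O)c3c(N)c(F)c(C(=O)O)c(F)c3o2)cc1F` carries a carboxy group. In a functional assay on HeLa cells (Homo sapiens) for cytotoxicity, read by neutral red uptake, with a stated time of 3 days (on this read-out lower numbers stand for stronger inhibition and higher numbers for weaker inhibition), compound 1 returns only a limit, > 100000 nM. In this assay compound 2 likewise returns only a limit, > 100000 nM. The measured step is a step that the two limits leave unreadable from compound 1 to compound 2; both values sit at the limit of > 100000 nM in this assay, at which 2 of the 2 values shown sit, so compound 2 stands at the limit of this assay rather than at a number. Compound 3 `CN(C)CC(=O)OCc1c(F)c(N)c2c(=O)cc(-c3ccc(N)c(F)c3)oc2c1F` has not yet been measured in this assay. It differs from compound 2 by ((((dimethylamino)methyl)carbonyl)oxy)methyl in place of carboxy on an aromatic carbon. Among the measured compounds shown here, the single measured step bears on this change only in that it alters the same aromatic carbon, and its size cannot be read, since both of its ends are limits. For the measured compounds named here, no measured step gives a direction or a size for the change to compound 3, so no step beyond the scatter can be foreseen. Compound 3 is therefore expected to come out near the limit as well, at about 150000 nM in this assay, within 20000 nM to 1000000 nM, which corresponds to an expected step that the limit leaves unreadable from compound 2 to compound 3.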

Compound 3, half-maximal inhibitory concentration: 9200 nM
The estimate for compound 3 lay 16-fold (1.21 log units) above the measured number; measured number below the stated range.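

In this assay, the aromatic carbon ortho to two fluoro groups proves to be a place where a change can move the read-out, which the earlier pair could not show: ((((dimethylamino)methyl)carbonyl)oxy)methyl in place of carboxy gives an at least 10-fold lower number from compound 2 to compound 3 (1.03 log units; beyond the scatter). The same group in place of chloro gives an at least 10-fold lower number from compound 1 to compound 3 (1.03 log units; beyond the scatter), so the shift appears against both earlier groups at this carbon. Compound 3 is the only compound shown that returns a number rather than a limit, so each step has a limit at one end: the limit of > 100000 nM in this assay, at which 2 of the 3 values shown sit.

The step between the chloro and carboxy compounds cannot be read, and the compounds shown do not say whether those two groups differ at this carbon. On these data alone, the entering group also differs from carboxy in several respects at once, so it remains open whether a simple aminomethyl group, a plain acetate ester without the dimethylamino nitrogen, or a longer chain ending in an amine would give a number like that of compound 3.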